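Ring size on the acyl group and kinase inhibition

The compounds below may be only part of what the source reports. "The series", "measured", "known", "first", "only" and "open" are said of these compounds alone.

Of the compounds shown here, three sharing one core have been measured in an assay on Sf9 cells for inhibition of mitogen-activated protein kinase kinase kinase 14 (Homo sapiens), read by ADP-Glo, with a stated time of 60 min; a lower number here means a stronger inhibitor, a higher number a weaker inhibitor. Compound 1 `CCCC(=O)n1nc(C)c(-c2ccc(Cl)c(Cl)c2)c1N` carries a propyl group on the carbonyl carbon; in this assay compound 1 reaches only > 100000 nM, which is a limit of the assay and not a number. Compound 2 `Cc1nn(C(=O)C2CC2)c(N)c1-c1ccc(Cl)c(Cl)c1`, with a cyclopropyl group in that place, gives 24300 nM. Compound 3 `Cc1nn(C(=O)C2CCC2)c(N)c1-c1ccc(Cl)c(Cl)c1`, with a cyclobutyl group there, gives 2900 nM. Of the two numbers shown compound 3 stands lowest, and its nearest neighbour is compound 2, separated by an 8.4-fold lower number from compound 2 to compound 3 (0.92 log units; beyond the scatter). The steps of an at least 4.1-fold lower number from compound 1 to compound 2 (0.61 log units; beyond the scatter) and an at least 34-fold lower number from compound 1 to compound 3 (1.53 log units; beyond the scatter) are each measured against a limit (the limit of > 100000 nM in this assay, at which 1 of the 3 values shown sits).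

Compound 4 `Cc1nn(C(=O)C2CCCCC2)c(N)c1-c1ccc(Cl)c(Cl)c1` has not yet been measured; it differs from compound 3 in one place: cyclohexyl in place of cyclobutyl on a carbonyl carbon. All measured steps concern the group on this carbonyl carbon, and each larger ring so far brought a lower number, most directly an 8.4-fold lower number from compound 2 to compound 3 (0.92 log units; beyond the scatter) in the closest pair. Going by the values given here, no measured compound goes against that direction, but none reaches a six-membered ring, so how far it carries beyond cyclobutyl remains open. On this basis a further modest fall is expected, a 2.4-fold lower number from compound 3 to compound 4 (0.38 log units; beyond the scatter). Compound 4 is therefore estimated at about 1200 nM in this assay, with a range from 250 nM to 8000 nM.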

Compound 4, half-maximal inhibitory concentration: 3300 nM
Estimate against measurement, compound 4: 2.8-fold (0.44 log units) below; measured number inside the range.
By their numbers in this assay, from the lowest: compounds 3 and 4 (each within the scatter of the next); then compound 2. At a limit, above all of these: compound 1.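

In this assay, the trend toward lower numbers with larger rings does not continue past cyclobutyl: a 1.1-fold higher number from compound 3 to compound 4 (0.06 log units; within the scatter), so on this carbonyl carbon cyclohexyl and cyclobutyl cannot be told apart. The six-membered ring nevertheless keeps the advantage over cyclopropyl that the four-membered ring had shown, with a 7.4-fold lower number from compound 2 to compound 4 (0.87 log units; beyond the scatter). The step of an at least 30-fold lower number from compound 1 to compound 4 (1.48 log units; beyond the scatter) gives only a bound, as compound 1 stands at a limit of the assay and not at a number: the limit of > 100000 nM in this assay, at which 1 of the 4 values shown sits.

Cyclopentyl, the one ring size still missing from this short series, is not among the compounds shown, and neither are phenyl, a branched chain such as tert-butyl, or an amine on the same carbonyl carbon, so it remains open whether any group here would bring a number clearly lower than those of compound 3 and compound 4. The compounds shown also vary only this one group, which leaves open whether the same order of the acyl groups would hold if the dichlorophenyl group or the amine of the shared core were replaced.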